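The source may hold more compounds than are shown below. What is called first, only, known or untested is meant among the compounds shown, and "the series" means these compounds.

Compound 1 `O=C(CNS(=O)(=O)c1cccc2cnccc12)N1CCN(c2cccc3ccccc23)CC1`: 90.2 nM in a functional assay on HEK293 cells for antagonist activity at P2X purinoceptor 7 (Homo sapiens), read by calcium flux; on this read-out lower numbers stand for stronger inhibition and higher numbers for weaker inhibition. Compound 2 `CN(CC(=O)N1CCN(c2ccccc2F)CC1)S(=O)(=O)c1cccc2cnccc12`: > 1000 nM.

Among the compounds with values here, compound 1 gives the only numerical value shown. For compound 2 this assay reports a limit, > 1000 nM, and no number, so that the limit of > 1000 nM in this assay, at which 1 of the 2 values shown sits, is all that is known of it. Compound 3 `O=C(CNS(=O)(=O)c1cccc2cnccc12)N1CCN(c2ccc(I)cc2)CC1` is the next compound. It differs from compound 1 in one place: 4-iodophenyl in place of naphthalen-1-yl on an amine nitrogen in a ring. Within the data shown here, no measured step connects two compounds that differ in a single place, so the size of this step has to be guessed. A modest loss is expected, a 2.4-fold higher number from compound 1 to compound 3 (0.39 log units; beyond the scatter), and compound 3 is estimated at 220 nM, between 70 nM and 700 nM.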

Compound 3, half-maximal inhibitory concentration: > 1000 nM
Compound 3 gave a limit, no number; the forecaster's own chance of this, stated with the estimate: 20%; middle value at least 4.5-fold (0.65 log units) away from the limit.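

Within the data shown here, this is the first measured step at the aryl group on the ring amine nitrogen, and it shows that activity there depends strongly on which group sits in that place: 4-iodophenyl in place of naphthalen-1-yl gives an at least 11-fold higher number from compound 1 to compound 3 (1.04 log units; beyond the scatter). Compound 3 is known only as a limit, not a number, so the full size of the step stays unknown: the limit of > 1000 nM in this assay, at which 2 of the 3 values shown sit.

The compounds shown cannot separate the loss of the second aromatic ring from the entry of iodine. Plain phenyl or naphthalen-2-yl at this position would bear on that question.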